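The source may hold more compounds than are shown below. What is called first, only, known or untested is meant among the compounds shown, and "the series" means these compounds.

Notes on the series. Among the compounds with values here, compound 1 `O=C1C(=O)N(Cc2ccc(-c3cncnc3)cc2)c2ccc(OC(F)(F)F)cc21` carries a pyrimidin-5-yl group on an aromatic carbon of a six-membered aromatic ring of carbon only, para to a large group; in a functional assay on CHO cells for positive allosteric modulation of muscarinic acetylcholine receptor M5 (Homo sapiens), read by FLIPR and calcium flux, with a stated time of 1 h (a lower number here means that less compound is needed, a higher number that more compound is needed for the effect), compound 1 gives 2100 nM, the only numerical result among the compounds measured so far. Compound 2 `O=C1C(=O)N(Cc2ccc(-c3cccnc3)cn2)c2ccc(OC(F)(F)F)cc21` is reported in this assay only as a limit, > 30000 nM. Compound 3 `O=C1C(=O)N(Cc2cccc(-c3ccccc3)c2)c2ccc(OC(F)(F)F)cc21` likewise reaches only the limit > 30000 nM in this assay. Within the data shown here, because of the limit of > 30000 nM in this assay, at which 2 of the 3 values shown sit, compound 1 is the sole anchor for comparison, and no step between two measured numbers is available in this assay.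

Compound 4 `COc1cccc(Oc2ccc(CN3C(=O)C(=O)c4cc(OC(F)(F)F)ccc43)cc2)n1` is the next compound for this assay. Its change from compound 1 is (6-methoxypyridin-2-yl)oxy in place of pyrimidin-5-yl on an aromatic carbon. Among the measured compounds shown here, no measured pair in the set shows what such an exchange does here, so the size of the step from compound 1 to compound 4 cannot be read from data and rests on expectation alone. The expected step is a 1.4-fold lower number from compound 1 to compound 4 (0.15 log units; within the scatter), leaning toward a lower number but not clearly beyond the scatter of this assay. Compound 4 is therefore estimated at about 1500 nM in this assay, with a range from 400 nM to 6000 nM, and with a real chance that the result is again reported only as a limit.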

Compound 4, half-maximal effective concentration: 2200 nM
Beside the measured number, compound 4's estimate is 1.5-fold (0.17 log units) below it, within the range that was stated.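

At the place para to a large group, on an aromatic carbon of a six-membered aromatic ring of carbon only, this assay gives a 1.0-fold higher number from compound 1 to compound 4 (0.02 log units; within the scatter) for (6-methoxypyridin-2-yl)oxy in place of pyrimidin-5-yl. Within the data shown here, this is the first step that can be read between two numbers, and it shows that this place gives a numerical result with either group, so the exchange leaves the read-out inside the scatter despite the differences in ring hetero atoms and in the atoms that enter. No steps to compound 2 or compound 3 can be read, because each stands only as a limit: the limit of > 30000 nM in this assay, at which 2 of the 4 values shown sit.

A single step cannot separate what the oxygen link and the methoxy group each contribute, so neither can be judged alone from these compounds. From the compounds shown here alone, it also remains open whether a morpholine, a carboxylic acid or a longer alkyl ether at this same place would keep a numerical result or move it beyond the scatter of this assay.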